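Para substituent swap on the shared core: nitro for fluoro

The compounds below may be only part of what the source reports. "The series", "measured", "known", "first", "only" and "open" are said of these compounds alone.

Among the compounds with values here, compound 3 `Oc1ccc2[nH]ncc2c1C(c1ccc(F)cc1)N1CCCCC1` gives 350 nM in an assay for inhibition of protein disulfide-isomerase (Homo sapiens), with a stated time of 1 h (a lower number here means a stronger inhibitor, a higher number a weaker inhibitor), the second highest of the three numbers so far. Compound 1 `Oc1ccc2[nH]ncc2c1C(c1ccc(-n2cccc2)cc1)N1CCCCC1` gives 290 nM, and the step of a 1.2-fold higher number from compound 1 to compound 3 (0.08 log units; within the scatter) is within the scatter. Compound 2 `Oc1ccc2[nH]ncc2c1C(c1ccc(C(F)(F)F)cc1)N1CCCCC1` gives 710 nM, and the step of a 2.0-fold lower number from compound 2 to compound 3 (0.31 log units; beyond the scatter) is modest. Compound 4 `O=[N+]([O-])c1ccc(C(c2c(O)ccc3[nH]ncc23)N2CCCCC2)cc1` carries the change (nitro in place of fluoro on an aromatic carbon). Within the data shown here, no measured step involves nitro; the nearest comparison is the step of a 2.0-fold lower number from compound 2 to compound 3 (0.31 log units; beyond the scatter), where a larger group at the same place gave a modestly higher number, so a small rise in this assay is expected, about a 1.4-fold higher number from compound 3 to compound 4 (0.15 log units; within the scatter). Compound 4 is estimated at 500 nM in this assay, with a range of 200 nM to 1400 nM.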

Compound 4, half-maximal inhibitory concentration: 520 nM
Estimate against measurement, compound 4: 1.0-fold (0.02 log units) below; the range from low to high includes it.
By their numbers in this assay, from the lowest: compounds 1, 3, 4 and 2 (each within the scatter of the next, the first and the last beyond it).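

In this assay nitro on this aromatic carbon, para to a large group, stays within the scatter of each of the three earlier groups (a 1.5-fold higher number from compound 3 to compound 4 (0.17 log units; within the scatter); a 1.4-fold lower number from compound 2 to compound 4 (0.14 log units; within the scatter); a 1.8-fold higher number from compound 1 to compound 4 (0.25 log units; within the scatter)). Fluoro and trifluoromethyl lie just beyond the scatter of each other, yet nitro falls within the scatter of both, so the four groups form a continuous, narrow spread rather than separate levels. Nothing available accounts for this spread.

Open, from the compounds shown here alone, is how an amine or a carboxylic acid at this place would read in this assay and whether either would give more than a modest step.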